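Amide to Urea: Following a Step from Compound 2

The source may report more compounds than this note shows. Statements on the series, on what has been measured and on what is new or still open speak of the compounds shown alone.

Measured compounds and their values:
compound 1, `COc1cc(Cl)cc(-c2nn(-c3cccc(NC(=O)c4cc(C(F)(F)F)cc(C(F)(F)F)c4)c3)cc2-c2ccncc2)c1`, 72.1%
compound 2, `COc1cc(Cl)cc(-c2nn(-c3cccc(NC(=O)c4ccc(Cl)c(Cl)c4)c3)cc2-c2ccncc2)c1`, 58.6%

Two compounds share a core and differ only in the acyl group attached to the amide nitrogen. In a functional assay on OVCAR-4 cells (Homo sapiens) for inhibition, read by sulforhodamine B assay, with a stated time of 48 h, tested at 10 uM (a higher number here means a weaker effect of the compound at the concentration tested, a lower number a stronger effect), compound 1 gives 72.1%, and compound 2 gives 58.6%. Compound 2 therefore holds the lower of the two numbers, and the gap to compound 1 lies beyond the usual scatter of this measurement, so the difference between the two readings is treated as real.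

Compound 3, `COc1cc(Cl)cc(-c2nn(-c3cccc(NC(=O)Nc4ccc(Cl)c(Cl)c4)c3)cc2-c2ccncc2)c1`, is not yet measured. Relative to compound 2 the change is (3,4-dichlorophenyl)amino in place of 3,4-dichlorophenyl on a carbonyl carbon. The acyl group and the remainder of the molecule are kept.

Among the measured compounds shown here, no measured pair in this set shows what this kind of change does in this assay, so any expectation rests on the change itself and on the position of compound 2. A step of modest size in either direction, quite possibly not beyond the scatter, is expected, and a reading on the weaker side of compound 2 is thought slightly more likely. For compound 3 the expected step is a number 4.4 percentage points higher from compound 2 to compound 3 (within the scatter). For compound 3 the estimate in this assay is 63%, with a range from 46% to 80%.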

Compound 3, a percentage reported as activity, at one concentration (the size of the read-out at that concentration, not a potency): 13.3%
Estimate against measurement, compound 3: 49.7 percentage points above, and the stated range ends above it.
By their numbers in this assay, from the lowest: compound 3; then compound 2; then compound 1.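

In this assay, placing (3,4-dichlorophenyl)amino in place of 3,4-dichlorophenyl on the carbonyl carbon gives a number 45.3 percentage points lower from compound 2 to compound 3 (beyond the scatter), turning the amide into a urea while the dichlorophenyl ring and the rest of the molecule stay the same. The earlier pair varied only the aryl group on the carbonyl, whereas this step shows that the read-out also responds strongly to the link between the carbonyl and that ring, here to the entry of a single nitrogen that brings one hydrogen-bond donor. Nothing available accounts for the size of this step, so the data record the change without explaining it.

The compounds shown leave open whether the urea has a similar effect with the aryl group of compound 1, or whether this step belongs to the 3,4-dichlorophenyl group alone. They also leave open whether the urea nitrogen hydrogen is needed, which a carbamate with an oxygen in that place, or a urea with a methyl group on that nitrogen, could test, and the same holds for a longer chain between the carbonyl and the ring.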